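Triazine piperazine series: cytotoxicity limits and a chloro shift

This account rests on a few compounds, and the source may have more. Where it says the series, first, only, none or still open, it means among the compounds named here.

compound 1, `Cc1ccc(-c2nnc(N3CCN(C(=O)CN4CCN(c5ccccc5)CC4)CC3)nc2-c2ccc(C)cc2)cc1`: in an ADME assay on NIH3T3 cells (Mus musculus) for cytotoxicity, read by MTT assay, with a stated time of 24 h (on this read-out lower numbers stand for stronger inhibition and higher numbers for weaker inhibition), compound 1 gives > 914000 nM, a limit of the assay.
compound 2, `COc1ccc(-c2nnc(N3CCN(C(=O)CN4CCN(c5ccccc5OC)CC4)CC3)nc2-c2ccc(OC)cc2)cc1`: in this assay compound 2 gives > 821000 nM, a limit of the assay.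
compound 3, `COc1ccc(-c2nnc(N3CCN(C(=O)CN4CCN(c5ccccc5Cl)CC4)CC3)nc2-c2ccc(OC)cc2)cc1`: in this assay compound 3 gives > 814000 nM, a limit of the assay.

All three values in this assay are limits, so compound 3 stands nowhere readable among them; it sits at the limit of > 814000 nM in this assay, at which 1 of the 3 values shown sits, compound 2 at the limit of > 821000 nM in this assay, at which 1 of the 3 values shown sits, and compound 1 at the limit of > 914000 nM in this assay, at which 1 of the 3 values shown sits. Among the compounds with values here, the one step in this assay between measured compounds, a step that the two limits leave unreadable from compound 2 to compound 3, is not readable because both ends are limits.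

Compound 4, `COc1ccc(-c2nnc(N3CCN(C(=O)CN4CCN(c5cccc(Cl)c5)CC4)CC3)nc2-c2ccc(OC)cc2)cc1`, differs from compound 3 by 3-chlorophenyl in place of 2-chlorophenyl on an amine nitrogen in a ring. Within the data shown here, no measured step bears on this change, and the step from compound 2 to compound 3 gives no readable size. With every value a limit, no step beyond the scatter is expected in this assay for compound 4, and the estimate is an at least 1.0-fold lower number from compound 3 to compound 4 (0.00 log units; that floor lies within the scatter). Compound 4 is expected at about 800000 nM, within 150000 nM to 1000000 nM, most probably again reported only as a limit.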

Compound 4, half-maximal inhibitory concentration: > 814000 nM
Compound 4 ended at the assay's limit; the forecaster's own chance of this, stated with the estimate: 85%; middle value at least 1.0-fold (0.00 log units) away from the limit.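

In this assay compound 4 gives > 814000 nM, a limit of the assay. The steps from compound 2 and compound 3 to compound 4 cannot be read, each joining two limits. Left open is whether 3-chlorophenyl and 2-chlorophenyl differ at all in this assay.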